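Urea nitrogen substituent: pentyl replaced by cyclohexyl

The compounds below may be only part of what the source reports. "The series", "measured", "known", "first", "only" and "open" are said of these compounds alone.

Three ureas on a shared core are in hand. Compound 1 `CCCCNC(=O)Nc1c(OCCCn2cnc(-c3ccccc3)c2)cccc1N(C)C` gives 140 nM in an assay for inhibition of acyl-CoA:cholesterol acyltransferase (Oryctolagus cuniculus), using microsomes; a higher number here means a weaker inhibitor, a lower number a stronger inhibitor; compound 2 `CCNC(=O)Nc1c(OCCCn2cnc(-c3ccccc3)c2)cccc1N(C)C` gives 870 nM in this assay; compound 3 `CCCCCNC(=O)Nc1c(OCCCn2cnc(-c3ccccc3)c2)cccc1N(C)C` gives 31 nM in this assay. Compound 3 stands lowest of the three, beyond the scatter from both others. The steps read a 6.2-fold higher number from compound 1 to compound 2 (0.79 log units; beyond the scatter), a 4.5-fold lower number from compound 1 to compound 3 (0.65 log units; beyond the scatter) and a 28-fold lower number from compound 2 to compound 3 (1.45 log units; beyond the scatter): longer chains on the urea nitrogen went with lower numbers across compounds 2, 1 and 3. Compound 4 `CN(C)c1cccc(OCCCn2cnc(-c3ccccc3)c2)c1NC(=O)NC1CCCCC1` carries cyclohexyl in place of pentyl on an amide-type nitrogen. Among the measured compounds shown here, no measured step trades a chain for a ring, so only the chain steps bear on it, and they give no direction for this swap. A step within the scatter is therefore expected, a 1.1-fold higher number from compound 3 to compound 4 (0.05 log units; within the scatter). In this assay compound 4 is expected to give 35 nM, with a range from 10 nM to 120 nM.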

Compound 4, half-maximal inhibitory concentration: 73 nM
For compound 4 the middle estimate is 2.1-fold (0.32 log units) below the measured one; the range from low to high includes it.
By their numbers in this assay, from the lowest: compound 3; then compounds 4 and 1 (each within the scatter of the next); then compound 2.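

On the amide-type nitrogen a ring is accepted: in this assay cyclohexyl gives up a modest amount against pentyl (a 2.4-fold higher number from compound 3 to compound 4 (0.37 log units; beyond the scatter)), keeps a large gain over ethyl (a 12-fold lower number from compound 2 to compound 4 (1.08 log units; beyond the scatter)) and stays within the scatter of butyl (a 1.9-fold lower number from compound 1 to compound 4 (0.28 log units; within the scatter)). Compound 4 goes against the link between more carbon and lower numbers seen in compounds 2, 1 and 3, so carbon count alone does not set the number here. No measurement offered here explains the gap between the ring and the chain.

As far as these compounds go, whether a longer chain such as hexyl would fall below compound 3 remains open. So does the reading for other rings on this nitrogen, such as cyclopentyl or phenyl.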